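This account rests on a few compounds, and the source may have more. Where it says the series, first, only, none or still open, it means among the compounds named here.

Of the compounds shown here, three have been tested so far in an ADME assay on PC-3 cells (Homo sapiens) for cytotoxicity, read by WST assay, tested at 100 uM; on this read-out higher numbers stand for more inhibition at the one concentration tested (going by the name of the read-out) and lower numbers for less inhibition. Compound 1 `O=C(Nc1ccc(Cl)cc1)C1CCCN(C(=O)c2cccc(-c3cccs3)c2)C1` gives 4% in this assay. Compound 2 `O=C(Nc1ccc(Cl)cc1)C1CCCN(C(=O)c2ccc(-c3ccco3)cc2)C1` gives 6% and compound 3 `CC(C)(C)OC(=O)c1cccc(NC(=O)C2CCCN(C(=O)c3cc(C(F)(F)F)cc(C(F)(F)F)c3)C2)c1` gives 0%, and both of these numbers lie within the usual scatter of the number for compound 1, so the three measured compounds cannot be told apart here; all of them leave the cells largely untouched at the concentration tested. Compound 4 `COCc1cccc(C(=O)N2CCCC(C(=O)Nc3ccc(Cl)cc3)C2)c1` has not yet been measured. It differs from compound 1 in one place: methoxymethyl in place of thiophen-2-yl on an aromatic carbon. Among the compounds with values here, no pair of measured compounds differs in only one place, so no measured step offers a direct guide. Every measured number sits near the bottom of the scale, and the expected step in this assay is no change at the digits printed from compound 1 to compound 4 (within the scatter), none beyond the scatter. Compound 4 is expected to give 4%, within a range from 0% to 12%.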

Compound 4, a percentage reported as inhibition, at one concentration (the size of the read-out at that concentration, not a potency): 0%
Estimate against measurement, compound 4: 4 percentage points above; low and high end bracket the measured number.
By their numbers in this assay, from the lowest: compounds 3, 4, 1 and 2 (each within the scatter of the next).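

In this assay, within the data shown here, the step at this position is the first direct comparison in one place (a number 4 percentage points lower from compound 1 to compound 4 (within the scatter)), and it lies within the scatter. At this aromatic carbon, methoxymethyl, which has no ring, cannot be told apart from the ring of thiophen-2-yl on this read-out. No measurement at hand explains this result.

As far as these compounds go, whether an amine or a carboxylic acid on this carbon would give a number beyond the scatter remains open. Also open, from the compounds shown here alone, is whether any group here would lift the read-out from the bottom of the scale.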